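From aminoethyl to hydrazone on a butyltellanyl aryl

The compounds below may be only part of what the source reports. "The series", "measured", "known", "first", "only" and "open" are said of these compounds alone.

Compound 1 `CCCC[Te]c1ccc(C(C)N)cc1`: 12.1 ug/mL in a functional assay, read by spectrophotometry, with a stated time of 30 min; on this read-out lower numbers stand for stronger inhibition and higher numbers for weaker inhibition
Compound 2 `CCCC[Te]c1cccc(/C(C)=N/O)c1`: 5.12 ug/mL
Compound 3 `CCCC[Se]c1ccc(C(C)N)cc1`: > 100 ug/mL, a limit of this assay

Compound 1 holds the highest of the two numbers shown; compound 2 sits lower, beyond the scatter. The value of compound 3 is a limit only. Compound 4 `CCCC[Te]c1ccc(/C(C)=N/N)cc1` differs from compound 1 by a group of 4 heavy atoms (2 carbon, 2 nitrogen; no ring) in place of a group of 3 heavy atoms (2 carbon, 1 nitrogen; no ring), on an aromatic carbon. Going by the values given here, no measured pair covers this change. Because compound 2 gives 5.12 ug/mL with a related imine-type group, a modest move toward stronger inhibition is expected, step a 1.7-fold lower number from compound 1 to compound 4 (0.24 log units; within the scatter) in this assay. Compound 4 is therefore estimated at 7 ug/mL, expected between 3 ug/mL and 20 ug/mL.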

Compound 4, half-maximal inhibitory concentration: 5.08 ug/mL
Beside the measured number, compound 4's estimate is 1.4-fold (0.14 log units) above it; measured number inside the range.
By their numbers in this assay, from the lowest: compounds 4 and 2 (each within the scatter of the next); then compound 1. At a limit, above all of these: compound 3.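

In this assay, the hydrazone group in place of 1-aminoethyl, on an aromatic carbon, gives a 2.4-fold lower number from compound 1 to compound 4 (0.38 log units; beyond the scatter). Going by these compounds alone, this is the only step that can be read here, and it shows that the 1-aminoethyl group is not needed at this position for inhibition on this read-out, since a group with a double bond outside the aromatic ring does better. On these data alone, how a carboxylic acid or a longer chain would fare at this position stays open. Steps to compound 3, whose value is a limit, cannot be read: the limit of > 100 ug/mL in this assay, at which 1 of the 4 values shown sits.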